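Replacing bromo with methyl in compound 3

The source may hold more compounds than are shown below. What is called first, only, known or untested is meant among the compounds shown, and "the series" means these compounds.

Within the data shown here, in a functional assay on DU-145 cells (Homo sapiens) for inhibition, read by MTT assay, with a stated time of 24 h (a higher number here means a weaker inhibitor, a lower number a stronger inhibitor), compound 3 `CCOC(=O)C1=Cc2ccccc2OC1(OCc1cc(-c2ccc(Br)cc2)no1)C(F)(F)F` gives 71700 nM, the only number in the set. Compound 1 `CCOC(=O)C1=Cc2ccccc2OC1(OCc1cn(CC(=O)Nc2ccccc2Br)nn1)C(F)(F)F` reaches only a limit of this assay, > 150000 nM. Compound 2 `CCOC(=O)C1=Cc2ccccc2OC1(OCc1cn(CC(=O)Nc2ccc(C)cc2)nn1)C(F)(F)F` likewise gives only a limit, > 150000 nM. The step that the two limits leave unreadable from compound 1 to compound 2 cannot be sized, since both values sit at the limit of > 150000 nM in this assay, at which 2 of the 3 values shown sit. Compound 4 `CCOC(=O)C1=Cc2ccccc2OC1(OCc1cc(-c2ccc(C)cc2)no1)C(F)(F)F` differs from compound 3 by methyl in place of bromo on an aromatic carbon. Among the measured compounds shown here, the only measured step resembling this change is the one from compound 1 to compound 2, and it gives no readable size; the set holds no other step in this assay. The expected step is therefore a 1.3-fold higher number from compound 3 to compound 4 (0.10 log units; within the scatter), nothing beyond the scatter. Compound 4 is estimated at 90000 nM, within 35000 nM to 200000 nM.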

Compound 4, half-maximal inhibitory concentration: > 150000 nM
Compound 4 ended at the assay's limit (the forecaster's own chance of this, stated with the estimate: 40%); middle value at least 1.6-fold (0.22 log units) away from the limit.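

In this assay, among these compounds, methyl in place of bromo on this aromatic carbon gives an at least 2.0-fold higher number from compound 3 to compound 4 (0.32 log units; beyond the scatter), the only readable step in the set, whereas the earlier pair of compounds gave no size. The 4-bromophenyl group therefore keeps a measurable number where 4-methylphenyl does not. The full size of the step stays unread, as the value of compound 4 is only a limit of the assay: the limit of > 150000 nM in this assay, at which 3 of the 4 values shown sit.

Going by these compounds, whether chloro, an amine or a carboxylic acid at this place would give a lower number than compound 3 remains open. So does whether any group here reaches far stronger inhibition.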